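The source may report more compounds than this note shows. Statements on the series, on what has been measured and on what is new or still open speak of the compounds shown alone.

Measured so far in an ADME assay on liver for metabolic stability, with Liver microsome (Homo sapiens) as the target, using microsomes (a lower number here means slower removal, a higher number faster removal of the compound), are three compounds:
Compound 1 `COc1ccc(C(=O)Nc2[nH]nc(-c3ccccn3)c2C2CC2)cc1` gives 12.8 mL.min-1.g-1
Compound 2 `N#Cc1ccc(C2CCN(C(=O)Nc3cc(-c4ccccn4)n[nH]3)CC2)cc1` gives 25.3 mL.min-1.g-1
Compound 3 `O=C(Nc1cc(-c2ccccn2)n[nH]1)N1CCN(c2ccc(F)cc2)CC1` gives 30.8 mL.min-1.g-1

Compound 2 stands within the usual scatter of both other compounds, so these three values give it no clear rank. Compound 4 `O=C(Nc1cc(-c2ccccn2)n[nH]1)N1CCC(Oc2ccccc2)CC1` has not yet been measured and carries phenoxy in place of 4-cyanophenyl on a saturated ring carbon in its structure. Going by the values given here, no measured pair differs in one place only, so no step in this assay can be read directly. A step no larger than the scatter is expected, with a slight lean toward compound 3 at 30.8 mL.min-1.g-1 on the scale. The expected 1.2-fold higher number from compound 2 to compound 4 (0.07 log units; within the scatter) lies within the scatter. For compound 4 the estimated value is 30 mL.min-1.g-1 with 15 mL.min-1.g-1 to 60 mL.min-1.g-1 as the expected range.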

Compound 4, intrinsic clearance in microsomes: 27.3 mL.min-1.g-1
Compound 4: middle estimate off by 1.1-fold (0.04 log units), on the high side, within the range that was stated.
By their numbers in this assay, from the lowest: compounds 1, 2, 4 and 3 (each within the scatter of the next, the first and the last beyond it).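

In this assay, going by these compounds alone, phenoxy in place of 4-cyanophenyl on a saturated ring carbon gives a 1.1-fold higher number from compound 2 to compound 4 (0.03 log units; within the scatter), the first step that can be read at this position. The nitrile leaves and an oxygen enters, yet the step stays within the scatter, so these two groups cannot be told apart here. Nothing measured here accounts for this result.

From the compounds shown here alone, whether an amine, a carboxylic acid or a longer chain on this saturated ring carbon would also stay within the scatter remains open. Compound 1 and compound 3 differ from these compounds in more than one place, so their steps cannot be read.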